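Predicting a Pyridin-2-yl Analogue in a Hydrolase Series

The compounds below may be only part of what the source reports. "The series", "measured", "known", "first", "only" and "open" are said of these compounds alone.

Of the compounds shown here, three have so far been tested in an assay on microsomes from brain for inhibition of Fatty-acid amide hydrolase 1 (Rattus norvegicus), read by fluorescence and HPLC, with a stated time of 60 min; on this read-out lower numbers stand for stronger inhibition and higher numbers for weaker inhibition. Compound 1 `CCCCCCCCc1ccc(OCC(=O)Cn2nnc(-c3ccc(S(=O)(=O)N(C)C)cc3)n2)cc1` gives 590 nM. Compound 2 `CCCCCCCCc1ccc(OCC(=O)Cn2nnc(C(=O)OC)n2)cc1` gives 88 nM in this assay, and compound 3 `CCCCCCCCc1ccc(OCC(=O)Cn2nnnc2C)cc1` gives 41 nM. The step of a 6.7-fold lower number from compound 1 to compound 2 (0.83 log units; beyond the scatter) and the step of a 2.1-fold lower number from compound 2 to compound 3 (0.33 log units; beyond the scatter) both moved the numbers downward, so compound 3 stands lowest of the three, separated from compound 2 and from compound 1 by gaps that lie beyond the scatter.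

The next compound, compound 4 `CCCCCCCCc1ccc(OCC(=O)Cn2nnnc2-c2ccccn2)cc1`, differs from compound 3 in one place: pyridin-2-yl in place of methyl on an aromatic carbon. Within the data shown here, no measured step repeats this exact exchange. The closest guide is a 6.7-fold lower number from compound 1 to compound 2 (0.83 log units; beyond the scatter), where a large aromatic group left the core, a small group entered, and the number fell. Here the reverse happens: a methyl of one heavy atom leaves and a six-membered aromatic ring of six heavy atoms enters, so a rise in the number is the more likely outcome, of modest size rather than large, since only a single step informs it. Compound 4 is therefore estimated to give 100 nM in this assay, within a range of 35 nM to 350 nM. This estimate corresponds to an expected step of a 2.4-fold higher number from compound 3 to compound 4 (0.39 log units; beyond the scatter).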

Compound 4, half-maximal inhibitory concentration: 880 nM
For compound 4 the middle estimate is 8.8-fold (0.94 log units) below the measured one; the whole stated range lies below it.
By their numbers in this assay, from the lowest: compound 3; then compound 2; then compounds 1 and 4 (each within the scatter of the next).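

Exchanging methyl for pyridin-2-yl on an aromatic carbon of the five-membered aromatic ring with 4 nitrogen gives a 21-fold higher number from compound 3 to compound 4 (1.33 log units; beyond the scatter) in this assay, so this carbon is highly sensitive to what it carries. Among these compounds, the earlier steps both moved the number downward and neither changed this carbon of compound 3, so this is the first direct reading of this position and the first step to move the number upward, and it is large. Nothing available here explains why a change of this kind at this carbon has so large an effect.

From the compounds shown here alone, what remains open is which feature of the new group matters: the size of the whole ring, or the ring nitrogen, which sits two ring bonds from the point of attachment. A phenyl ring or a pyridin-4-yl ring on the same carbon would help to separate these two readings, while an ethyl or a cyclopropyl group would show whether the number already climbs with a much smaller step up from methyl.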